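Moving the amine one carbon outward in a biphenyl amide series

The compounds below may be only part of what the source reports. "The series", "measured", "known", "first", "only" and "open" are said of these compounds alone.

Measured compounds:
compound 1, `CC(C)C[C@H](N)CN(C(=O)[C@@H]1C[C@H]1c1ccccc1)c1ccc(-c2ccccc2)cc1` — 880 nM
compound 2, `CC(C)C[C@H](N)CCN(C(=O)[C@@H]1C[C@H]1c1ccccc1)c1ccc(-c2ccccc2)cc1` — 3 nM

In a functional assay for agonist activity at G protein-coupled receptor 88 (Homo sapiens), read by HTRF and cAMP accumulation (on this read-out lower numbers stand for an effect already at smaller amounts and higher numbers for an effect only at larger amounts of compound), compound 1 gives 880 nM, the higher of the two numbers, while compound 2 gives 3 nM. Going by the values given here, the one measured step, a 290-fold lower number from compound 1 to compound 2 (2.47 log units; beyond the scatter), comes from placing the amine one carbon further from the amide-type nitrogen. Compound 3, `CC(C)CCNCCN(C(=O)[C@@H]1C[C@H]1c1ccccc1)c1ccc(-c2ccccc2)cc1`, differs from compound 1 in the same region: (isopentylamino)methyl in place of 1-amino-3-methylbutyl on a saturated chain carbon bound to an amide-type nitrogen. Compound 3 thus shares with compound 2 the longer spacing between the amine and the amide-type nitrogen, but carries the isopentyl on the amine itself and has no stereocentre. The step from compound 1 to compound 2 bears on this change; as the spacing is the common feature, a large drop in number is expected, though the altered amine substitution leaves the size uncertain. Compound 3 is therefore expected at 40 nM in this assay, in the range 5 nM to 300 nM, corresponding to a 22-fold lower number from compound 1 to compound 3 (1.34 log units; beyond the scatter).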

Compound 3, half-maximal effective concentration: 5.1 nM
Estimate against measurement, compound 3: 7.8-fold (0.89 log units) above; the measured number falls inside the stated range.
By their numbers in this assay, from the lowest: compounds 2 and 3 (each within the scatter of the next); then compound 1.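

In this assay, a 170-fold lower number from compound 1 to compound 3 (2.24 log units; beyond the scatter) shows that a large step also appears when the amine carries the isopentyl group itself and the defined stereocentre of 1-amino-3-methylbutyl is absent. The a 1.7-fold higher number from compound 2 to compound 3 (0.23 log units; within the scatter) stays within the usual scatter, so compound 2 and compound 3 cannot be told apart here, and neither the placement of the isobutyl-type side chain on the carbon chain nor that stereocentre separates them on this read-out. No supporting evidence bears on the reason for these numbers.

On these data alone, it remains open whether a shorter group on the amine, such as methyl, or a ring such as cyclohexyl, would fit in place of isopentyl. A dimethylamino group and a still longer chain carrying the amine also remain untested in the compounds shown.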